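The source may hold more compounds than are shown below. What is called first, only, known or untested is meant among the compounds shown, and "the series" means these compounds.

Compound 1 `CN(C)C1(Cc2ccccc2)CCN(c2cc(C(F)(F)F)ccc2CNC(=O)Nc2cccc3ccc(O)cc23)CC1`: 8.9 nM
Compound 2 `CN(C)C1(Cc2ccccc2)CCN(c2cc(C(F)(F)F)ccc2CNC(=O)Nc2ccc3ccncc3c2)CC1`: 56.1 nM

Among the compounds with values here, in an assay on CHO cells for antagonist activity at transient receptor potential cation channel subfamily V member 1 (Homo sapiens), read by scintillation counting, with a stated time of 5 min, in the presence of a further agent that is not named here (on this read-out higher numbers stand for an effect only at larger amounts of compound and lower numbers for an effect already at smaller amounts), compound 2 stands at the higher of the two numbers; its only neighbour is compound 1, and the step between them is a 6.3-fold higher number from compound 1 to compound 2 (0.80 log units; beyond the scatter). Compound 3 `CN(C)C1(Cc2ccccc2)CCN(c2cc(C(F)(F)F)ccc2CNC(=O)Nc2cccc3cnccc23)CC1` is the next member of the series; the change from compound 2 is isoquinolin-5-yl in place of isoquinolin-7-yl on an amide-type nitrogen. Within the data shown here, no measured step bears directly on this change. Among the measured compounds shown here, the single step available, a 6.3-fold higher number from compound 1 to compound 2 (0.80 log units; beyond the scatter), exchanges one bicyclic aryl group for another of different make-up, whereas compound 2 and compound 3 contain the same atoms joined differently. That step therefore gives neither a direction nor a size for the present one. The working expectation is that compound 3 lands near compound 2, so the step of a 1.1-fold lower number from compound 2 to compound 3 (0.05 log units; within the scatter) is expected to stay within the scatter, with a wide range kept in either direction. Compound 3 is expected to give 50 nM in this assay, between 10 nM and 250 nM.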

Compound 3, half-maximal effective concentration: 8.8 nM
Compound 3: the middle estimate sits 5.7-fold (0.75 log units) above what was measured; the measured number lies below the stated range.
By their numbers in this assay, from the lowest: compounds 3 and 1 (each within the scatter of the next); then compound 2.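

In this assay the position is sensitive to how the bicyclic group is joined, not only to which atoms it holds: with the same atoms, isoquinolin-5-yl in place of isoquinolin-7-yl on the amide-type nitrogen gives a 6.4-fold lower number from compound 2 to compound 3 (0.80 log units; beyond the scatter) at an otherwise unchanged core. Isoquinolin-5-yl in place of 7-hydroxynaphthalen-1-yl gives a 1.0-fold lower number from compound 1 to compound 3 (0.00 log units; within the scatter) and so stays within the scatter, which means an isoquinoline group does not by itself go with the higher number of compound 2. Nothing available accounts for the difference between the two isoquinoline groups.

Open, going by these compounds, is how isoquinolin-6-yl or quinolin-5-yl would read at this nitrogen. Also open, on these data alone, is whether an amine or a methoxy group on the isoquinolin-5-yl group would keep the number of compound 3.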